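The compounds below may be only part of what the source reports. "The series", "measured", "known", "first", "only" and "open" are said of these compounds alone.

- compound 1 `BrCCCOc1c(Br)cc(Br)cc1Oc1ccc(Br)cc1Br`: 30.3 ug/mL
- compound 2 `BrCCOc1c(Br)cc(Br)cc1Oc1ccc(Br)cc1Br`: 32.5 ug/mL
- compound 3 `Brc1ccc(Oc2cc(Br)cc(Br)c2OCc2ccccc2)c(Br)c1`: not yet measured

For the measured compounds named here, in a functional assay on U-937 cells (Homo sapiens) for cytotoxicity, read by MTT assay, with a stated time of 24 h (a higher number here means a weaker inhibitor, a lower number a stronger inhibitor), compound 2 cannot be separated from compound 1, the only other measured compound: a 1.1-fold higher number from compound 1 to compound 2 (0.03 log units; within the scatter). The next change is phenyl in place of bromomethyl on a saturated chain carbon bound to an oxygen on an aromatic ring, or 2-bromoethoxy to benzyloxy. Going by the values given here, only one measured step bears on this, a 1.1-fold higher number from compound 1 to compound 2 (0.03 log units; within the scatter), and it bears only in part: it also alters this chain, but no aromatic ring enters. Among the compounds with values here, no measured compound carries a ring here, so the direction stays open and no step beyond the scatter is firmly expected. The expected result is a 1.1-fold lower number from compound 2 to compound 3 (0.03 log units; within the scatter). For compound 3 the estimate in this assay is 30 ug/mL, with an expected range of 12 ug/mL to 75 ug/mL.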

Compound 3, half-maximal inhibitory concentration: 29 ug/mL
Estimate against measurement, compound 3: 1.0-fold (0.01 log units) above, and the stated range covers the measured number.
By their numbers in this assay, from the lowest: compounds 3, 1 and 2 (each within the scatter of the next).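

In this assay, phenyl in place of bromomethyl on a saturated chain carbon bound to an oxygen on an aromatic ring gives a 1.1-fold lower number from compound 2 to compound 3 (0.05 log units; within the scatter), and phenyl in place of 2-bromoethyl at the same place gives a 1.0-fold lower number from compound 1 to compound 3 (0.02 log units; within the scatter). The earlier pair carried no ring at this position; these steps show that 2-bromoethoxy or the longer bromo chain can give way to benzyloxy, with its six-membered aromatic ring of carbon only, without a step beyond the scatter. No available measurement accounts for this result.

As far as these compounds go, with all three compounds within the scatter of one another, it remains open whether any group at this position can move the number in this assay at all. Also open, from the compounds shown here alone, is what an amine or a carboxylic acid at the chain end, or a longer chain, would give.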